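Working notes: compound 3 to compound 4 in this series

The compounds below may be only part of what the source reports. "The series", "measured", "known", "first", "only" and "open" are said of these compounds alone.

Measured so far:
Compound 1 `Cn1c(Cc2nn(C)c(=O)c3ccccc23)nnc1SCCCCCCCC(=O)Nc1ccc(I)cc1` gives 1300 nM.
Compound 2 `CC(C)Oc1ccc(NC(=O)CCCCCCCSc2nnc(Cc3nn(C)c(=O)c4ccccc34)n2C)cc1` gives 1100 nM.
Compound 3 `Cn1c(Cc2nn(C)c(=O)c3ccccc23)nnc1SCCCCCCCC(=O)Nc1ccccc1O` gives 27000 nM.

In an assay on isolated protein (Mus musculus) for inhibition of IL15-IL15 receptor (Homo sapiens), read by resazurin assay, with stated times of 30 min and 2.5 days (a lower number here means a stronger inhibitor, a higher number a weaker inhibitor), compound 3 stands highest of the three; the steps of a 21-fold higher number from compound 1 to compound 3 (1.32 log units; beyond the scatter) and a 25-fold higher number from compound 2 to compound 3 (1.39 log units; beyond the scatter) are both large, while a 1.2-fold lower number from compound 1 to compound 2 (0.07 log units; within the scatter) is within the scatter. Compound 4 `Cn1c(Cc2nn(C)c(=O)c3ccccc23)nnc1SCCCCCCCC(=O)Oc1ccc(Cl)cc1Cl` differs from compound 3 by 2,4-dichlorophenoxy in place of (2-hydroxyphenyl)amino on a carbonyl carbon. Going by the values given here, no measured step changes an amide to an ester, so that part is untested here. The two large steps bear on the aryl group: moving away from 2-hydroxyphenyl to a 4-substituted phenyl lowered the number strongly in both cases. A drop is therefore expected for compound 4, tempered by the untested ester, with the expected step of a 7.7-fold lower number from compound 3 to compound 4 (0.89 log units; beyond the scatter). Compound 4 is estimated at 3500 nM, range 900 nM to 14000 nM.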

Compound 4, half-maximal inhibitory concentration: 800 nM
Compound 4: middle estimate off by 4.4-fold (0.64 log units), on the high side; measured number below the stated range.
By their numbers in this assay, from the lowest: compounds 4, 2 and 1 (each within the scatter of the next); then compound 3.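

The change at this carbonyl carbon tolerates loss of the amide hydrogen: 2,4-dichlorophenoxy gives a 34-fold lower number from compound 3 to compound 4 (1.53 log units; beyond the scatter) and so joins the low group. The ester also matches both 4-substituted amides, with a 1.4-fold lower number from compound 2 to compound 4 (0.14 log units; within the scatter) and a 1.6-fold lower number from compound 1 to compound 4 (0.21 log units; within the scatter) both within the scatter. No supporting data explain these steps.

Each step changes the linking atom and the aryl group together, so their separate contributions remain unresolved. Also open, on these data alone, is how a carboxylic acid at this carbonyl carbon or a longer chain would read.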